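Removing the Ethoxy Group from Compound 3

The source may hold more compounds than are shown below. What is called first, only, known or untested is meant among the compounds shown, and "the series" means these compounds.

Compound 1, `COc1cc(C(=O)c2sc(-c3ccc(C(F)(F)F)cc3)cc2N)cc(OC)c1OC`: 540 nM
Compound 2, `COc1cc(C(=O)c2sc(-c3cc(OC)c(OC)c(OC)c3)cc2N)cc(OC)c1OC`: 3500 nM
Compound 3, `CCOc1ccc(-c2cc(N)c(C(=O)c3cc(OC)c(OC)c(OC)c3)s2)cc1`: 510 nM

In a functional assay on FM3A cells (Mus musculus) for antiproliferative activity (a higher number here means a weaker inhibitor, a lower number a stronger inhibitor), compound 3 gives the lowest of the three numbers, though compound 1 sits within the scatter of it, while compound 2 lies well beyond. Compound 4, `COc1cc(C(=O)c2sc(-c3ccccc3)cc2N)cc(OC)c1OC`, differs from compound 3 by hydrogen in place of ethoxy on an aromatic carbon. Among the measured compounds shown here, only one measured step touches the same position: a 1.1-fold lower number from compound 1 to compound 3 (0.02 log units; within the scatter). For the measured compounds named here, that step swapped one group for another without a change beyond the scatter, which suggests the group at this position has little weight here, but no step removes it entirely, so some uncertainty remains. The expected step is a 1.5-fold higher number from compound 3 to compound 4 (0.17 log units; within the scatter), leaning slightly weaker. Compound 4 is therefore estimated at 750 nM, with a range from 250 nM to 2300 nM.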

Compound 4, half-maximal inhibitory concentration: 13 nM
Beside the measured number, compound 4's estimate is 58-fold (1.76 log units) above it, outside the stated range (below it).
By their numbers in this assay, from the lowest: compound 4; then compounds 3 and 1 (each within the scatter of the next); then compound 2.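

Removing the ethoxy gives a 39-fold lower number from compound 3 to compound 4 (1.59 log units; beyond the scatter) and removing the trifluoromethyl gives a 42-fold lower number from compound 1 to compound 4 (1.62 log units; beyond the scatter) so this position matters far more than the earlier swap suggested. That swap only compared two groups with each other: their numbers lie within the scatter, and only the plain phenyl of compound 4 reveals how much higher both are than with hydrogen. Nothing available here explains this gap. On these data alone, whether a single fluorine atom or a methyl group at this place keeps the number near that of compound 4 remains open. So does the outcome with an amine there.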